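Swapping the amide substituent onto the methoxy-bearing core

The compounds below may be only part of what the source reports. "The series", "measured", "known", "first", "only" and "open" are said of these compounds alone.

Compound 1 `COCCNC(=O)c1cc2cccc(OC)c2oc1=N` stands higher of the two compounds measured in an assay on HEK293 cells for displacement of a labelled ligand from adenosine receptor A2b (Homo sapiens), read by scintillation counting, with a stated time of 30 min, tested at 10 uM; on this read-out higher numbers stand for more inhibition at the one concentration tested (going by the name of the read-out) and lower numbers for less inhibition: compound 1 gives 43%, while compound 2 `CCC(CO)NC(=O)c1cc2cc(Br)ccc2oc1=N` gives 4%, a gap beyond the usual scatter. Compound 3 `CCC(CO)NC(=O)c1cc2cccc(OC)c2oc1=N` keeps the core of compound 1 and carries the amide substituent of compound 2. The change from compound 1 is 1-(hydroxymethyl)propyl in place of 2-methoxyethyl on an amide-type nitrogen. Going by the values given here, no measured pair isolates this change on this core, so its effect is untested. Because compound 2 with this group on a different core gave 4%, a modest lowering is expected, a number 13 percentage points lower from compound 1 to compound 3 (beyond the scatter). Compound 3 is estimated at 30%, between 5% and 55%.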

Compound 3, a percentage reported as inhibition, at one concentration (the size of the read-out at that concentration, not a potency): 39%
The estimate for compound 3 lay 9 percentage points below the measured number; low and high end bracket the measured number.
By their numbers in this assay, from the lowest: compound 2; then compounds 3 and 1 (each within the scatter of the next).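

In this assay, placing 1-(hydroxymethyl)propyl in place of 2-methoxyethyl on the amide-type nitrogen gives a number 4 percentage points lower from compound 1 to compound 3 (within the scatter). On this core, the two groups cannot be told apart by this read-out, although the entering group carries a hydrogen-bond donor that the leaving group lacks. No supporting measurement bears on why they read alike. Still open, as far as these compounds go, is whether a chain ending in an amine or a carboxylic acid, or a longer alkyl chain, on the same nitrogen would also leave the number within the scatter.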